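Swapping the pyridine for a benzoxazole on the piperazine

The source may report more compounds than this note shows. Statements on the series, on what has been measured and on what is new or still open speak of the compounds shown alone.

Of the compounds shown here, two with a shared core have been measured in an assay on isolated protein for binding affinity to 5-hydroxytryptamine receptor 7 (Rattus norvegicus); on this read-out lower numbers stand for stronger inhibition and higher numbers for weaker inhibition. Compound 1 `COc1ccccc1N1CCN(CCCCC(=O)c2ccccc2O)CC1` gives 16.4 nM. Compound 2 `O=C(CCCCCN1CCN(c2ccccn2)CC1)c1ccccc1O` gives 105 nM, the higher of the two numbers, and its distance from compound 1 lies beyond the usual scatter of such measurements. Compound 3 `O=C(CCCCCN1CCN(c2nc3ccccc3o2)CC1)c1ccccc1O` has not been measured yet. It differs from compound 2 in one place: 1,3-benzoxazol-2-yl in place of pyridin-2-yl on an amine nitrogen in a ring. Within the data shown here, no measured pair shows this kind of change here, so there is nothing to lean on but the two values above. With the substituent on the ring nitrogen growing from one aromatic ring to two, the expectation is a modest move toward stronger binding in this assay, a step of about a 1.9-fold lower number from compound 2 to compound 3 (0.28 log units; within the scatter), which may well stay within the scatter. Compound 3 is therefore estimated at 55 nM, with a plausible range from 15 nM to 220 nM.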

Compound 3, inhibition constant: 148 nM
Compound 3: the middle estimate sits 2.7-fold (0.43 log units) below what was measured, within the range that was stated.
By their numbers in this assay, from the lowest: compound 1; then compounds 2 and 3 (each within the scatter of the next).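

On the amine nitrogen of the six-membered ring, 1,3-benzoxazol-2-yl in place of pyridin-2-yl gives a 1.4-fold higher number from compound 2 to compound 3 (0.15 log units; within the scatter) in this assay, so compound 2 and compound 3 cannot be told apart on this read-out. At this position, then, going from a single aromatic ring to a fused pair of aromatic rings, with a further hydrogen-bond acceptor, leaves the inhibition constant unchanged within the scatter. No measurement at hand explains why this larger group makes no clear difference.

Still open, on these data alone, is whether a group with no aromatic ring on this nitrogen, such as cyclohexyl or acetyl, would shift the number beyond the scatter. Also open, as far as these compounds go, is whether the same swap gives a similar step when the shared core carries a longer chain.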